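Methoxy for methylamino on the shared nucleoside core

This account rests on a few compounds, and the source may have more. Where it says the series, first, only, none or still open, it means among the compounds named here.

Measured compounds in a functional assay on A549 cells (Homo sapiens), read by MTT assay, with a stated time of 72 h; a higher number here means a weaker inhibitor, a lower number a stronger inhibitor:
compound 1 `COc1ncnc2c1c(-c1ccsc1)cn2[C@@H]1O[C@H](CO)[C@@H](O)[C@H]1O`: 5170 nM
compound 2 `COc1ncnc2c1c(-c1ccoc1)cn2[C@@H]1O[C@H](CO)[C@@H](O)[C@H]1O`: 1160 nM
compound 3 `C#Cc1cn([C@@H]2O[C@H](CO)[C@@H](O)[C@H]2O)c2ncnc(NC)c12`: only a limit, > 20000 nM

Compound 3 sits at the limit of this assay, as shown by the limit of > 20000 nM in this assay, at which 1 of the 3 values shown sits, so no number is known for it. Compound 4 `C#Cc1cn([C@@H]2O[C@H](CO)[C@@H](O)[C@H]2O)c2ncnc(OC)c12` differs from compound 3 in one place: methoxy in place of methylamino on an aromatic carbon.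

For the measured compounds named here, the only measured step, a 4.5-fold lower number from compound 1 to compound 2 (0.65 log units; beyond the scatter), concerns a different position and does not bear on the methylamino-to-methoxy change; no measured pair isolates that change. Compounds 1 and 2 carry methoxy at the same place but differ from compound 3 elsewhere, so their values give only a loose anchor.

With nothing in the measured steps to size this change, the direction is open. Compound 4 is expected to give about 10000 nM in this assay, within 2000 nM to 40000 nM, which means an estimated at least 2.0-fold lower number from compound 3 to compound 4 (0.30 log units; that floor lies within the scatter); a limit value for compound 4 remains a real possibility.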

Compound 4, half-maximal inhibitory concentration: 8160 nM
Estimate against measurement, compound 4: 1.2-fold (0.09 log units) above; the range from low to high includes it.
By their numbers in this assay, from the lowest: compound 2; then compounds 1 and 4 (each within the scatter of the next). At a limit, above all of these: compound 3.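

In this assay, methoxy in place of methylamino on the aromatic carbon next to the ring nitrogen gives an at least 2.4-fold lower number from compound 3 to compound 4 (0.38 log units; beyond the scatter), so with ethynyl held fixed the change lowers the number, though its size remains only a bound. Compound 3 stays a limit, not a number: the limit of > 20000 nM in this assay, at which 1 of the 4 values shown sits. With methoxy held fixed, ethynyl in place of furan-3-yl gives a 7.0-fold higher number from compound 2 to compound 4 (0.85 log units; beyond the scatter), while ethynyl in place of thiophen-3-yl gives a 1.6-fold higher number from compound 1 to compound 4 (0.20 log units; within the scatter), so only furan-3-yl separates from ethynyl beyond the scatter.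

Going by these compounds, whether the methylamino-to-methoxy change would run the same way with furan-3-yl or thiophen-3-yl in place of ethynyl stays open, with the change seen on this one pair only. Also open, on these data alone, is how a primary amine or a longer ether such as ethoxy would compare at this position.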